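Removing the propanoyl group from compound 3

A few compounds are considered here, and "the series" means these few. Any claim that something is new, unique, unknown or untested is made for them only; others in the source may bear on it.

In a functional assay on BGC-823 cells (Homo sapiens) for inhibition, read by MTT assay, with a stated time of 72 h (on this read-out lower numbers stand for stronger inhibition and higher numbers for weaker inhibition), compound 1 `O=C1Nc2ccccc2/C1=C\C(=O)c1cccc(Cl)c1` gives 7700 nM, compound 2 `O=C1Nc2ccccc2/C1=C\C(=O)c1cc(F)cc(F)c1` gives 15700 nM and compound 3 `CCC(=O)Nc1cccc(C(=O)/C=C2/C(=O)Nc3ccccc32)c1` gives 7500 nM. Compound 3 thus sits level with compound 1 within the scatter, while compound 2 has the higher number, beyond the scatter.

Next is compound 4 `Nc1cccc(C(=O)/C=C2/C(=O)Nc3ccccc32)c1`, with hydrogen in place of propanoyl on a nitrogen on an aromatic ring. Within the data shown here, the one measured step, a 1.0-fold lower number from compound 1 to compound 3 (0.01 log units; within the scatter), put propanoylamino in place of chloro on an aromatic carbon and stayed within the scatter. Among the measured compounds shown here, no measured step removes the propanoyl alone, so this step bears only indirectly. With it as the guide, no change beyond the scatter is expected in this assay. The estimated step is a 1.1-fold higher number from compound 3 to compound 4 (0.03 log units; within the scatter). For compound 4 the estimate is 8000 nM, with an expected range of 3000 nM to 20000 nM.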

Compound 4, half-maximal inhibitory concentration: 29900 nM
Estimate against measurement, compound 4: 3.7-fold (0.57 log units) below; the measured number lies above the stated range.
By their numbers in this assay, from the lowest: compounds 3 and 1 (each within the scatter of the next); then compounds 2 and 4 (each within the scatter of the next).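

In this assay, among these compounds, the propanoyl on the nitrogen matters: replacing it with hydrogen gives a 4.0-fold higher number from compound 3 to compound 4 (0.60 log units; beyond the scatter), the first step at this position beyond the scatter. The free amino group also separates from chloro, with a 3.9-fold higher number from compound 1 to compound 4 (0.59 log units; beyond the scatter), whereas propanoylamino and chloro had stayed level. This position therefore responds to its substituent, and here the propanoylamino group holds the lower number. Nothing available accounts for the shift. Going by these compounds, it remains open whether an acetyl group, a longer butanoyl chain or a methanesulfonyl group on that nitrogen would hold the number of compound 3.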